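The compounds below may be only part of what the source reports. "The series", "measured", "known", "first", "only" and "open" are said of these compounds alone.

Measured so far:
- Compound 1 `Nc1scc(-c2cccc(Cl)c2)c1C(=O)c1ccccc1` gives 45% in a functional assay on CHO cells for agonist activity at adenosine receptor A1 (Homo sapiens), read by fluorescence and ERK phosphorylation, with stated times of 30 min and 1.5 h, tested at 3 uM; on this read-out lower numbers stand for a weaker effect and higher numbers for a stronger effect at the one concentration tested.
- Compound 2 `Nc1scc(-c2cccc(Br)c2)c1C(=O)c1ccccc1` gives 67% in this assay.

Compound 2 stands highest of the two numbers shown; its nearest neighbour is compound 1, and the one measured step, a number 22 percentage points higher from compound 1 to compound 2 (beyond the scatter), lies beyond the scatter. Among the measured compounds shown here, that step is the only comparison on record, and it concerns one halogen replaced by another.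

Compound 3 `Nc1scc(-c2cccc([N+](=O)[O-])c2)c1C(=O)c1ccccc1` has not yet been measured in this assay. It differs from compound 2 as follows: nitro in place of bromo on an aromatic carbon. For the measured compounds named here, the halogen step does not transfer cleanly to this change, since nitro is neither of the two groups compared there, so no measured step speaks to it directly. With nothing to anchor a direction, the step expected is a number 17 percentage points lower from compound 2 to compound 3 (beyond the scatter), and the range is left wide. For compound 3 a value of 50% is estimated, between 20% and 80%.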

Compound 3, a percentage reported as activity, at one concentration (the size of the read-out at that concentration, not a potency): 47%
For compound 3 the middle estimate is 3 percentage points above the measured one; low and high end bracket the measured number.
By their numbers in this assay, from the lowest: compounds 1 and 3 (each within the scatter of the next); then compound 2.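

In this assay, the position meta to a large group now has a comparison beyond the halogens: nitro in place of bromo gives a number 20 percentage points lower from compound 2 to compound 3 (beyond the scatter) and so the higher number is not kept on leaving bromo for this group. Nitro in place of chloro gives a number 2 percentage points higher from compound 1 to compound 3 (within the scatter) and so compound 1 and compound 3 cannot be told apart, leaving compound 2 alone beyond the scatter of the other two compounds. Nothing measured here bears on the reason for these differences.

As far as these compounds go, whether an amine, a carboxylic acid or iodo at this position would read with compound 2 or with the other two compounds stays open. Also open, from the compounds shown here alone, is whether the same order would hold across a range of concentrations, since each number comes from a single concentration and is not a potency.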